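The source may hold more compounds than are shown below. What is called first, only, known or untested is meant among the compounds shown, and "the series" means these compounds.

Measured so far in a functional assay on HL-60 cells (Homo sapiens) for antiproliferative activity, with a stated time of 72 h; a lower number here means a stronger inhibitor, a higher number a weaker inhibitor:
compound 1 `COc1cc(OC)c(C(=O)/C=C/c2ccccc2Cl)c(O)c1CN1CCCC1`: 14200 nM
compound 2 `COc1cc(OC)c(C(=O)/C=C/c2ccccc2Cl)c(O)c1CN(C)CC(=O)O`: 80300 nM
compound 3 `CCN(CC)Cc1c(OC)cc(OC)c(C(=O)/C=C/c2ccccc2Cl)c1O`: 30900 nM

Compound 3, at 30900 nM, holds the middle of the three numbers, with compound 1 lower and compound 2 higher. The next analogue, compound 4 `COc1cc(OC)c(C(=O)/C=C/c2ccccc2Cl)c(O)c1CN(C)CCCN(C)C`, keeps the shared core and differs from compound 3 only in the amine: (3-(dimethylamino)propyl)(methyl)amino in place of diethylamino on a saturated chain carbon bound to an aromatic carbon.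

Going by the values given here, three measured steps bear on this place. They are a 2.2-fold higher number from compound 1 to compound 3 (0.34 log units; beyond the scatter), a 2.6-fold lower number from compound 2 to compound 3 (0.41 log units; beyond the scatter) and a 5.7-fold higher number from compound 1 to compound 2 (0.75 log units; beyond the scatter). All three are modest, so a modest step is also expected here. Among the compounds with values here, no measured compound carries the (3-(dimethylamino)propyl)(methyl)amino group, which leaves the direction uncertain. A lean towards a lower number is the working expectation, since compound 1 shows that a change from diethylamino can give a lower number, at 14200 nM. The expected step is a 2.1-fold lower number from compound 3 to compound 4 (0.31 log units; beyond the scatter). For compound 4 the estimated value is 15000 nM, with an expected range of 5000 nM to 45000 nM.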

Compound 4, half-maximal inhibitory concentration: 11400 nM
Compound 4: middle estimate off by 1.3-fold (0.12 log units), on the high side; measured number inside the range.
By their numbers in this assay, from the lowest: compounds 4 and 1 (each within the scatter of the next); then compound 3; then compound 2.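

In this assay, on a saturated chain carbon bound to an aromatic carbon, (3-(dimethylamino)propyl)(methyl)amino in place of diethylamino gives a 2.7-fold lower number from compound 3 to compound 4 (0.43 log units; beyond the scatter), so an open-chain amine at this place can reach the level of the pyrrolidin-1-yl compound: a 1.2-fold lower number from compound 1 to compound 4 (0.10 log units; within the scatter) leaves compound 1 and compound 4 indistinguishable. Against the carboxylic acid of compound 2, 2-(dimethylamino)ethyl in place of carboxy gives a 7.0-fold lower number from compound 2 to compound 4 (0.85 log units; beyond the scatter), the widest step seen at this place so far. No data on hand explain why these amines differ.

Still open, on these data alone, is whether the second amine nitrogen of compound 4 contributes at all, which a plain butyl chain on the same nitrogen would test. A shorter or longer chain between the two nitrogens, or a piperazine or morpholine ring on the same carbon, also remains to be placed in the series.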